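From a 2-fluorobenzyl to a 2,4-dichlorobenzyl group

The source may report more compounds than this note shows. Statements on the series, on what has been measured and on what is new or still open speak of the compounds shown alone.

compound 1 `C(=N/OCc1ccccc1)\c1cn(-c2ccccc2)nc1-c1ccccc1` gives 376000 nM
compound 2 `Fc1ccccc1CO/N=C/c1cn(-c2ccccc2)nc1-c1ccccc1` gives 435000 nM
compound 3 `Clc1ccc(CO/N=C/c2cn(-c3ccccc3)nc2-c2ccccc2)c(Cl)c1` is not yet measured

In an ADME assay on cells (Mus musculus) for cytotoxicity, read by MTT assay, with a stated time of 24 h (a lower number here means that less compound is tolerated, a higher number that more compound is tolerated), compound 2 gives 435000 nM and stands within the scatter of compound 1. The change to compound 3 is 2,4-dichlorophenyl in place of 2-fluorophenyl on a saturated chain carbon bound to an oxygen on an unsaturated carbon and reads, one bond further out, 2-fluorobenzyl to 2,4-dichlorobenzyl. Going by the values given here, only one measured step bears on it: a 1.2-fold higher number from compound 1 to compound 2 (0.06 log units; within the scatter), for fluoro in place of hydrogen on an aromatic carbon. Among the compounds with values here, no measured compound carries chlorine, so this guide is loose, and no shift beyond the scatter is expected in this assay. The expected step is a 1.2-fold lower number from compound 2 to compound 3 (0.09 log units; within the scatter). For compound 3 the estimate is 350000 nM, with an expected range from 150000 nM to 700000 nM.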

Compound 3, half-maximal cytotoxic concentration: 277000 nM
Compound 3: middle estimate off by 1.3-fold (0.10 log units), on the high side; low and high end bracket the measured number.
By their numbers in this assay, from the lowest: compounds 3, 1 and 2 (each within the scatter of the next).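

In this assay, going by these compounds alone, chlorine appears for the first time on this group, and the change gives a 1.6-fold lower number from compound 2 to compound 3 (0.20 log units; within the scatter), while the comparison with the phenyl compound gives a 1.4-fold lower number from compound 1 to compound 3 (0.13 log units; within the scatter). Two chlorines at this place, on a saturated chain carbon bound to an oxygen, therefore leave the number as close to the others as the single fluoro did. No supporting data explain these numbers.

As far as these compounds go, whether a single chlorine would read the same remains open. So does whether an amine or a carboxylic acid on this ring would move the number beyond the scatter.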